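The source may report more compounds than this note shows. Statements on the series, on what has been measured and on what is new or still open speak of the compounds shown alone.

Three compounds have been measured in a functional assay on HL-60 cells (Homo sapiens) for inhibition, read by CCK-8 assay, with a stated time of 72 h, tested at 20 uM; a higher number here means more inhibition of growth at the concentration tested, a lower number less inhibition of growth:

- compound 1 `CC(C)(C)OC(=O)/C=C1/C(=O)Nc2ccccc21` gives 94.5%
- compound 2 `CCCCc1ccc2c(c1)/C(=C\C(=O)OC(C)(C)C)C(=O)N2` gives 94.7%
- compound 3 `COc1ccc2c(c1)/C(=C\C(=O)OC(C)(C)C)C(=O)N2` gives 94.2%

All three numbers lie close together. Compound 1 stands between the other two: the step of a number 0.2 percentage points higher from compound 1 to compound 2 (within the scatter) and the step of a number 0.3 percentage points lower from compound 1 to compound 3 (within the scatter) are both within the usual scatter, so nothing separates compound 1 from either neighbour. The step of a number 0.5 percentage points lower from compound 2 to compound 3 (within the scatter) is likewise within the scatter.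

Compound 4 `CC(C)(C)OC(=O)/C=C1/C(=O)Nc2ccc(Cl)cc21` is not yet measured. It differs from compound 1 in one place: chloro in place of hydrogen on an aromatic carbon. Within the data shown here, the steps that bear on this are the two substitutions at the same kind of aromatic carbon already seen, from compound 1 to compound 2 and from compound 1 to compound 3, and neither moved the number beyond the scatter. A chloro group is smaller than butyl and, like methoxy, a single substituent on the ring, so no step beyond the scatter is expected here either; the expected step is a number 0.5 percentage points lower from compound 1 to compound 4 (within the scatter). Compound 4 is therefore estimated at 94%, with a range from 87% to 98%.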

Compound 4, percent growth inhibition at one concentration: 94.9%
Beside the measured number, compound 4's estimate is 0.9 percentage points below it; the range from low to high includes it.
By their numbers in this assay, from the lowest: compounds 3, 1, 2 and 4 (each within the scatter of the next).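

Chloro is a third kind of group on this aromatic carbon, a halogen after a chain and an ether, and it too leaves the reading in this assay unchanged within the scatter: a number 0.4 percentage points higher from compound 1 to compound 4 (within the scatter). The direct swaps tell the same story, with a number 0.7 percentage points higher from compound 3 to compound 4 (within the scatter) and a number 0.2 percentage points higher from compound 2 to compound 4 (within the scatter), so hydrogen, butyl, methoxy and chloro cannot be told apart here. No supporting evidence bears on why this position tolerates such different groups.

As far as these compounds go, whether an amine or a carboxylic acid on this carbon would move the number beyond the scatter remains open. All four compounds also sit close together at a single tested concentration, so any real differences among them could only show up in a measurement that spans several concentrations.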